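Cytotoxicity in THP-1 cells: a phenethyl amide analogue

The compounds below may be only part of what the source reports. "The series", "measured", "known", "first", "only" and "open" are said of these compounds alone.

Compound 1: `COc1ccccc1-c1cnc(NC(=O)c2ccc(F)cc2)n1C`, > 100000 nM
Compound 2: `COc1ccc(-c2cnc(NC(=O)C3CCCCC3)n2C)cc1`, > 100000 nM
Compound 3: `COc1ccc(CNC(=O)NC(=O)c2ccc(F)cc2)cc1`, > 50000 nM

Three compounds have been examined in a toxicity assay on THP-1 cells (Homo sapiens) for inhibition; a lower number here means that less compound is tolerated, a higher number that more compound is tolerated. Compound 1 reaches only the limit of the assay, > 100000 nM. Compound 2 likewise reaches only the limit, > 100000 nM, and so gives no number of its own. Compound 3 sits at a different limit, > 50000 nM, again without a number. Among the compounds with values here, compound 2 therefore stands with the pair at the limit of > 100000 nM in this assay, at which 2 of the 3 values shown sit, while the limit of > 50000 nM in this assay, at which 1 of the 3 values shown sits, holds the third compound; none of the three offers a measured value, and no step between them can be sized.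

Compound 4, `COc1ccc(-c2cnc(NC(=O)CCc3ccccc3)n2C)cc1`, is not yet measured in this assay. It keeps the core of compound 2 and differs only at the carbonyl carbon whose other neighbour is the amide-type nitrogen: phenethyl in place of cyclohexyl on a carbonyl carbon. Within the data shown here, with all three measured compounds at a limit, no precedent for a change beyond the scatter is available. Compound 4 is expected to remain at the limit as well, so that the step of a number no higher from compound 2 to compound 4 (the limit leaves the size open) is expected to be none beyond the scatter. Compound 4 is estimated at 100000 nM, within 40000 nM to 300000 nM.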

Compound 4, half-maximal cytotoxic concentration: > 100000 nM
Compound 4 gave a limit, no number; the forecaster's own chance of this, stated with the estimate: 80%; the middle value lies on the limit itself.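

Within the data shown here, compound 2 and compound 4 both stop at a limit rather than a number, so no step between them can be read for phenethyl in place of cyclohexyl. The compounds shown leave open at what concentration, if any, each would become toxic to these cells.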